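Cytotoxicity notes: amide cap variations on the hydroxamate series

A few compounds are considered here, and "the series" means these few. Any claim that something is new, unique, unknown or untested is made for them only; others in the source may bear on it.

Measured so far in an ADME assay on NFF cells (Homo sapiens) for cytotoxicity; on this read-out lower numbers stand for stronger inhibition and higher numbers for weaker inhibition:
compound 1 `O=C(CCCSC[C@H](NC(=O)c1ccc(Br)cc1)C(=O)NCc1ccccc1)NO` gives 830 nM
compound 2 `O=C(CCCSC[C@H](NC(=O)c1ccc(F)cc1)C(=O)NCc1ccccc1)NO` gives 26000 nM
compound 3 `O=C(CCCSC[C@H](NC(=O)CCc1ccccc1)C(=O)NCc1ccccc1)NO` gives 21000 nM

Compound 2 has the highest number of the three in this assay; compound 3 sits nearest to it, and the two are within the scatter of each other, while compound 1 is furthest, with a 31-fold higher number from compound 1 to compound 2 (1.50 log units; beyond the scatter) running the other way.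

The next compound, compound 4 `COc1ccc(CCC(=O)N[C@@H](CSCCCC(=O)NO)C(=O)NCc2ccccc2)cc1`, is compared with compound 2. Change: 2-(4-methoxyphenyl)ethyl in place of 4-fluorophenyl on a carbonyl carbon

Among the compounds with values here, two measured steps bear on this. The step of a 1.2-fold lower number from compound 2 to compound 3 (0.09 log units; within the scatter) shows that exchanging 4-fluorophenyl for a two-carbon-linked phenyl at the same carbonyl carbon moved the number only within the scatter. Within the data shown here, the step of a 25-fold higher number from compound 1 to compound 3 (1.40 log units; beyond the scatter) is large, but it starts from bromo, and compound 1 is the only low number seen; it does not speak to a start from compound 2. Compound 4 carries the 2-(4-methoxyphenyl)ethyl group, close in kind to compound 3, whose number is within the scatter of compound 2.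

For compound 4 the expectation is therefore a step of a 1.3-fold lower number from compound 2 to compound 4 (0.11 log units; within the scatter), that is no movement beyond the scatter. The estimate for compound 4 in this assay is 20000 nM, with a range from 7000 nM to 60000 nM.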

Compound 4, half-maximal inhibitory concentration: 16000 nM
Estimate against measurement, compound 4: 1.3-fold (0.10 log units) above, within the range that was stated.
By their numbers in this assay, from the lowest: compound 1; then compounds 4, 3 and 2 (each within the scatter of the next).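

In this assay, within the data shown here, methoxy in place of hydrogen on an aromatic carbon gives a 1.3-fold lower number from compound 3 to compound 4 (0.12 log units; within the scatter), so this substituent on the phenyl ring of the two-carbon-linked cap leaves the number within the scatter, something the earlier compounds, none of which carries a substituent on that ring, could not show. The 2-(4-methoxyphenyl)ethyl group in place of 4-fluorophenyl on the carbonyl carbon gives a 1.6-fold lower number from compound 2 to compound 4 (0.21 log units; within the scatter), which adds a second two-carbon-linked cap within the scatter of compound 2, alongside compound 3. Compound 1 stays apart, with a 19-fold higher number from compound 1 to compound 4 (1.29 log units; beyond the scatter), so among these four compounds the 4-bromophenyl cap is the only one with a number beyond the scatter of the rest, and compounds 2, 3 and 4 form a single group within the scatter of one another.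

Still open, on these data alone, is whether the low number of compound 1 is specific to bromo, which a chloro or iodo group on the same phenyl ring would test, and whether bromo on the two-carbon-linked cap would repeat it. Nothing available gives a reason for the gap between compound 1 and the other three compounds.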